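Iodo in Place of Cyclohexyl on a Growth Inhibitor

This account rests on a few compounds, and the source may have more. Where it says the series, first, only, none or still open, it means among the compounds named here.

Compound 1 `CC(C)(C)c1ccc(NC2=NCCO2)cc1` gives 2400 nM
Compound 2 `O=C(CCl)NC(=O)Nc1ccc(C2CCCCC2)cc1` gives 900 nM
Compound 3 `O=C(CCl)NC(=O)Nc1cccc(OC2CCCCC2)c1` gives 2700 nM

These three numbers all come from a functional assay on M21 cells (Homo sapiens) for inhibition, read by sulforhodamine B assay, with a stated time of 48 h (on this read-out higher numbers stand for weaker inhibition of growth and lower numbers for stronger inhibition of growth), and are the only ones available. Compound 2 at 900 nM holds the lowest number of the set, and the numbers of the other two compounds both lie beyond the scatter from it.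

Compound 4 `O=C(CCl)NC(=O)Nc1ccc(I)cc1` has not yet been measured. It differs from compound 2 by iodo in place of cyclohexyl on an aromatic carbon and keeps the rest of the structure. Within the data shown here, no pair of measured compounds differs in one place only, so the data offer no direct guide to this change. Compound 2 already sits at the low end of the set, so a higher number, meaning weaker inhibition of growth, seems the likelier direction. The expected step is a 2.2-fold higher number from compound 2 to compound 4 (0.35 log units; beyond the scatter) and would lie modestly beyond the scatter. Compound 4 is expected at 2000 nM in this assay with an estimated range from 700 nM to 5000 nM around that value.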

Compound 4, concentration for 50% growth inhibition: 4200 nM
The estimate for compound 4 lay 2.1-fold (0.32 log units) below the measured number; the measured number falls inside the stated range.
By their numbers in this assay, from the lowest: compound 2; then compounds 1, 3 and 4 (each within the scatter of the next).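

In this assay, exchanging cyclohexyl for iodo on the aromatic carbon para to a group of 8 heavy atoms gives a 4.7-fold higher number from compound 2 to compound 4 (0.67 log units; beyond the scatter), a step toward weaker inhibition of growth that lies beyond the scatter. Among these compounds, this is the first pair in the set that differs in one place only, and it shows that the group at this position affects the number while the rest of the structure stays the same. The data give no measured property that would account for the size of this step.

A single pair cannot show whether the trend follows ring size, the number of heavy atoms or something else. It also leaves open how other groups at this position, such as cyclopentyl, phenyl, an amine or a carboxylic acid, would compare with cyclohexyl and iodo.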